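A few compounds are considered here, and "the series" means these few. Any claim that something is new, unique, unknown or untested is made for them only; others in the source may bear on it.

Compound 1, with the structure `Nc1cc(N)c2nc(-c3ccccc3)c(NCc3ccc(Cl)c(Cl)c3)nc2c1`, is one of two compounds that have been tested in a functional assay on Malme-3M cells (Homo sapiens) for inhibition, read by sulforhodamine B assay, with a stated time of 48 h (on this read-out lower numbers stand for higher toxicity in this test and higher numbers for lower toxicity in this test), and in this assay compound 1 gives 50100 nM. The other is compound 2, with the structure `CCOC(=O)[C@H](CCC(=O)O)NC(=O)c1ccc(CNc2nc3cc(N)cc(N)c3nc2-c2ccccc2)cc1`, which in this assay gives 74100 nM. The two numbers lie within the scatter of each other, so neither compound can be set apart from the other on this read-out; compound 1 simply stands alongside compound 2 at the same level.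

Compound 3, with the structure `COc1ccc(CNc2nc3cc(N)cc(N)c3nc2-c2ccccc2)cc1`, has not yet been measured in this assay. It keeps the core of compound 1 and differs from it in one place: 4-methoxyphenyl in place of 3,4-dichlorophenyl on a saturated chain carbon bound to a nitrogen on an aromatic ring. For the measured compounds named here, no pair of measured compounds here shows how a change of this kind plays out, so the size of the step has to be guessed. A small move toward a higher number is expected for compound 3 in this assay, a step from compound 1 to compound 3 of a 1.4-fold higher number from compound 1 to compound 3 (0.16 log units; within the scatter), which would not go clearly beyond the scatter. The estimate for compound 3 is therefore 72000 nM, with a range from 30000 nM to 160000 nM.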

Compound 3, concentration lethal to 50% of the cells: 47900 nM
The estimate for compound 3 lay 1.5-fold (0.18 log units) above the measured number; low and high end bracket the measured number.
By their numbers in this assay, from the lowest: compounds 3, 1 and 2 (each within the scatter of the next).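

In this assay, for the compounds shown here, the change of 4-methoxyphenyl in place of 3,4-dichlorophenyl on a saturated chain carbon bound to a nitrogen on an aromatic ring comes to a 1.0-fold lower number from compound 1 to compound 3 (0.02 log units; within the scatter), the first step that can be read at this position. It shows that these two groups, each of 8 heavy atoms and each with one six-membered aromatic ring of carbon only, cannot be told apart on this read-out, even though the entering group brings oxygen and one hydrogen-bond acceptor where the leaving group has two chlorine atoms and none. Nothing in the data given explains why the two groups read alike.

Going by these compounds alone, this single step covers only two groups on the shared core, so it remains open whether a benzyl group carrying an amine or a carboxylic acid, or a longer chain in place of the single saturated chain carbon, would take the number in this assay beyond the scatter. As far as these compounds go, it also remains open whether either of the two halves of the change, removing the two chlorine atoms or adding the methoxy group, would read the same when made alone.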